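The source may hold more compounds than are shown below. What is called first, only, known or untested is meant among the compounds shown, and "the series" means these compounds.

Measured compounds: compound 1 `COc1cc2c(Oc3ccc(NC(=O)c4cc(-c5ccccc5)ccn4)cc3F)ccnc2cc1OCCCN1CCCC1` with 130 nM; compound 2 `COc1cc2c(Oc3ccc(NC(=O)c4cc(-c5ccccc5C)ccn4)cc3F)ccnc2cc1OCCCN1CCCC1` with 420 nM; compound 3 `COc1cc2c(Oc3ccc(NC(=O)c4nccc(-c5ccccc5)n4)cc3F)ccnc2cc1OCCCN1CCCC1` with 1120 nM, all in a functional assay on NCI-H460 cells (Homo sapiens) for cytotoxicity, read by MTT assay, with a stated time of 72 h; on this read-out lower numbers stand for stronger inhibition and higher numbers for weaker inhibition.

Compound 1 and compound 3 differ in the core, (4-phenylpyrimidin-2-yl in place of 4-phenylpyridin-2-yl on a carbonyl carbon), and this gave an 8.6-fold higher number from compound 1 to compound 3 (0.94 log units; beyond the scatter), leaving compound 3 with the highest number of the three. Compound 2 carries methyl in place of hydrogen on an aromatic carbon, which gave a 3.2-fold higher number from compound 1 to compound 2 (0.51 log units; beyond the scatter). Compound 4 `COc1cc2c(Oc3ccc(NC(=O)c4nccc(-c5ccc(C)cc5)n4)cc3F)ccnc2cc1OCCCN1CCCC1` is not yet measured; it carries methyl in place of hydrogen on an aromatic carbon. This is the same kind of change as that from compound 1 to compound 2, though not the same: in compound 2 the methyl sits ortho to a large group, in compound 4 para to a large group. Resting on the weakening seen as a 3.2-fold higher number from compound 1 to compound 2 (0.51 log units; beyond the scatter), a step of similar direction, a 2.0-fold higher number from compound 3 to compound 4 (0.29 log units; within the scatter), is expected. Compound 4 is therefore estimated at 2200 nM, between 900 nM and 5500 nM.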

Compound 4, half-maximal inhibitory concentration: 440 nM
Beside the measured number, compound 4's estimate is 5.0-fold (0.70 log units) above it; the whole stated range lies above it.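

In this assay, methyl in place of hydrogen on an aromatic carbon did not behave alike on the two cores. The new result, a 2.5-fold lower number from compound 3 to compound 4 (0.41 log units; beyond the scatter), runs opposite to the earlier step, so the effect of this change cannot simply be carried from one core to the other: the same change on two cores in this assay, a 3.2-fold higher number (0.51 log units; beyond the scatter) from compound 1 to compound 2 and a 2.5-fold lower number (0.41 log units; beyond the scatter) from compound 3 to compound 4, 8.2-fold (0.92 log units) apart, beyond the scatter of two such steps. This does not show that the core alone sets the outcome, as the methyl of compound 4 sits para to a large group and that of compound 2 does not, so core and methyl place change together.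

Going by these compounds, whether methyl at one fixed place would give the same direction on both cores remains open. So does how a methoxy group or a chlorine atom would behave on the phenyl ring of either core.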